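Methoxy replacement for the piperidinylmethoxy group in the sulfonamide series

The compounds below may be only part of what the source reports. "The series", "measured", "known", "first", "only" and "open" are said of these compounds alone.

Measured so far in an ADME assay on Caco-2 cells (Homo sapiens) for permeability, read by LC-MS, in the apical to basolateral direction, with a stated time of 90 min; a higher number here means that the compound crosses the layer faster, a lower number that the compound crosses the layer more slowly:
compound 1 `COc1ncc(-c2cc(OC3CCN(C)CC3)c3ncnc(C)c3c2)cc1NS(=O)(=O)c1ccc(F)cc1F` gives 4.5 10^-6 cm/s
compound 2 `COc1ncc(-c2cc(OCC3CCN(C)CC3)c3ncnc(C)c3c2)cc1NS(=O)(=O)c1ccc(F)cc1F` gives 8.8 10^-6 cm/s

Compound 2 holds the higher of the two numbers in this assay, but its distance from compound 1 is small: the step of a 2.0-fold higher number from compound 1 to compound 2 (0.29 log units; within the scatter) stays within the scatter, so the two compounds are not separated by the data.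

Compound 3 `COc1ncc(-c2cc(OC)c3ncnc(C)c3c2)cc1NS(=O)(=O)c1ccc(F)cc1F` is the next member. Relative to compound 2 the change is hydrogen in place of 1-methylpiperidin-4-yl on a saturated chain carbon bound to an oxygen on an aromatic ring.

Within the data shown here, only one measured step exists, and it alters the same part of the molecule by inserting a single chain carbon rather than removing the whole ring. Among the measured compounds shown here, no measured step removes a ring of this kind, so the expectation for compound 3 rests on the value of compound 2 in this assay alone, with the room for a larger shift left open.

For compound 3 the expected step is a 1.4-fold higher number from compound 2 to compound 3 (0.13 log units; within the scatter). Compound 3 is therefore estimated at 12 10^-6 cm/s, with a range from 5 10^-6 cm/s to 30 10^-6 cm/s.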

Compound 3, apparent permeability: 35 10^-6 cm/s
For compound 3 the middle estimate is 2.9-fold (0.46 log units) below the measured one, outside the stated range (above it).
By their numbers in this assay, from the lowest: compounds 1 and 2 (each within the scatter of the next); then compound 3.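

Working notes on the oxygen-linked substituent. In this assay, hydrogen in place of 1-methylpiperidin-4-yl on the saturated chain carbon gives a clear separation (a 4.0-fold higher number from compound 2 to compound 3 (0.60 log units; beyond the scatter)), whereas the earlier change of a single chain carbon left compound 1 and compound 2 within the scatter of each other. Methyl in place of 1-methylpiperidin-4-yl on the oxygen gives a step of the same direction (a 7.8-fold higher number from compound 1 to compound 3 (0.89 log units; beyond the scatter)), so compound 3 stands apart from both piperidine-bearing compounds. Among these three compounds, the change that separates the numbers at this position is therefore the step to methoxy from either piperidine-bearing group, not the presence or absence of the extra chain carbon, and no measured evidence accounts for the shift.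

The compounds shown do not tell whether the higher number goes with losing the ring nitrogen or the whole ring, a distinction that a tetrahydropyran-4-ylmethoxy group at this place could address. They also leave open how the numbers run for groups of intermediate size, such as ethoxy or an open-chain dimethylaminoethoxy group.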